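The compounds below may be only part of what the source reports. "The series", "measured", "known", "first", "only" and "open" are said of these compounds alone.

For the measured compounds named here, compound 2 `Cc1ccc(C(=O)Nc2cccc(/C=C/C(=O)c3nc4ccccc4[nH]3)c2)cc1` is one of two compounds measured in a functional assay on HCT-116 cells (Homo sapiens) for antiproliferative activity, read by MTT assay, with a stated time of 48 h; a higher number here means a weaker inhibitor, a lower number a stronger inhibitor; in that assay compound 2 gives 1660 nM, the highest of the two numbers, though its neighbour compound 1 `O=C(Nc1cccc(/C=C/C(=O)c2nc3ccccc3[nH]2)c1)c1cccc(Br)c1` is within the scatter, since compound 1 gives 1560 nM. Going by the values given here, the only measured step here, a 1.1-fold higher number from compound 1 to compound 2 (0.03 log units; within the scatter), exchanges one aryl group for another on the same carbonyl carbon and moves the number by an amount that counts as no change.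

Compound 3 `O=C(Nc1cccc(/C=C/C(=O)c2nc3ccccc3[nH]2)c1)c1cccc(C(F)(F)F)c1` differs from compound 2 in exactly that position: 3-(trifluoromethyl)phenyl in place of 4-methylphenyl on a carbonyl carbon. Among the compounds with values here, no measured step pairs a 3-(trifluoromethyl)phenyl group with anything, so the expectation rests on the one exchange seen, which left the number essentially where it was. The expected step of a 1.0-fold lower number from compound 2 to compound 3 (0.02 log units; within the scatter) is therefore no change beyond the scatter in this assay. On that basis compound 3 is estimated to give 1600 nM in this assay, with a range from 700 nM to 3600 nM.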

Compound 3, half-maximal inhibitory concentration: 3360 nM
Estimate against measurement, compound 3: 2.1-fold (0.32 log units) below; measured number inside the range.
By their numbers in this assay, from the lowest: compounds 1 and 2 (each within the scatter of the next); then compound 3.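

In this assay the aryl group on this carbonyl carbon is not indifferent after all: the earlier exchange left the number unchanged within the scatter, whereas a 2.0-fold higher number from compound 2 to compound 3 (0.31 log units; beyond the scatter) is a modest weakening beyond it. The step from the 3-bromophenyl group gives a similar picture, since trifluoromethyl in place of bromo on an aromatic carbon produces a 2.2-fold higher number from compound 1 to compound 3 (0.33 log units; beyond the scatter), and here only the substituent changes. Compound 3 is therefore the weakest of the three, although both steps are modest.

Nothing available explains the weakening seen with this exchange.

As far as these compounds go, three aryl groups cannot show whether the trend extends to other substituents, so it remains open how a 3-methoxyphenyl group, a 3-aminophenyl group or a plain phenyl group would compare. From the compounds shown here alone, it is also open whether a 4-(trifluoromethyl)phenyl group would behave like the 3-(trifluoromethyl)phenyl group, a question that decides whether the weakening follows the substituent itself or where it sits on the ring.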